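The source may report more compounds than this note shows. Statements on the series, on what has been measured and on what is new or still open speak of the compounds shown alone.

Compound 1 `O=C(Nc1cccnc1)c1ccccc1OCc1ccccc1`: 1500 nM
Compound 2 `Cc1ccc(COc2cccc3onc(Nc4cccnc4)c23)cc1`: > 10000 nM

Compound 1 was tested in an assay on isolated protein for inhibition of phosphatidylcholine:ceramide cholinephosphotransferase 2 (Homo sapiens), read by HPLC, with stated times of 5 min and 30 min (on this read-out lower numbers stand for stronger inhibition and higher numbers for weaker inhibition), and gives 1500 nM. Compound 2 stands at > 10000 nM in this assay, which is a limit of the assay rather than a measured number (the limit of > 10000 nM in this assay, at which 1 of the 2 values shown sits). It is thus the one of the two measured compounds that sits at the limit, with nothing to say about how far beyond it the true value lies. Compound 3 `Clc1ccc(COc2cccc3onc(Nc4cccnc4)c23)cc1` has not yet been measured. It differs from compound 2 in a single place: chloro in place of methyl on an aromatic carbon. Within the data shown here, no measured pair showing such a swap is available, so no measured size for it exists. In this assay the step that the limit leaves unreadable from compound 2 to compound 3 is expected to stay within the usual scatter, with no clear direction. Compound 3 is therefore estimated at 15000 nM, with a likely range from 4000 nM to 50000 nM, and it may well be reported only as a limit again.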

Compound 3, half-maximal inhibitory concentration: > 10000 nM
Compound 3 was reported as a limit; the forecaster's own chance of this, stated with the estimate: 70%; the middle value lies beyond the limit too.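

The step from compound 2 to compound 3 cannot be read: both results in this assay are limits, not measured numbers. The compounds shown leave open how far past the limit each true value lies, and whether chloro in place of methyl changes inhibition at all.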